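The source may hold more compounds than are shown below. What is called first, only, known or untested is meant among the compounds shown, and "the series" means these compounds.

Working notes on the series. The shared core carries an aryl-substituted pyrazole; compound 1, `Cc1nn(Cc2ccccc2)c(C)c1-c1ccc(N2CCc3cccc(C(=O)Nc4nc5ccccc5s4)c3C2)nc1C(=O)O`, bears two methyl groups and a benzyl group on that ring. In a functional assay on MOLT-4 cells (Homo sapiens) for antiproliferative activity, read by luminescence and CellTiter-Glo, with a stated time of 48 h, in the presence of a further agent that is not named here (on this read-out higher numbers stand for an effect only at larger amounts of compound and lower numbers for an effect already at smaller amounts), compound 1 gives only a limit of the assay, > 5000 nM, and no number. Compound 2, `Cc1c(-c2ccc(N3CCc4cccc(C(=O)Nc5nc6ccccc6s5)c4C3)nc2C(=O)O)cnn1CC1CCCCC1`, carries a single methyl and a cyclohexylmethyl group on the same ring, and in this assay compound 2 gives 197 nM. Among the measured compounds shown here, these two values are the only ones in hand, and no single-point step connects them, so they show merely that a mono-methyl pyrazole can reach a measurable value while the dimethyl benzyl analogue does not.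

Compound 3, `Cc1nn(Cc2ccccc2)cc1-c1ccc(N2CCc3cccc(C(=O)Nc4nc5ccccc5s4)c3C2)nc1C(=O)O`, differs from compound 1 by hydrogen in place of methyl on an aromatic carbon, on the aromatic carbon next to the ring nitrogen and next to the ring atom that bears the benzyl group. This leaves compound 3 with one methyl, as in compound 2. For the measured compounds named here, no measured step of this kind exists, so the size of the change is uncertain; a gain beyond the usual scatter is expected, though its extent is open. Compound 3 is therefore expected to give roughly 2000 nM, in the range 400 nM to 8000 nM, an expected step of an at least 2.5-fold lower number from compound 1 to compound 3 (0.39 log units; beyond the scatter).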

Compound 3, half-maximal effective concentration: > 5000 nM
Compound 3 was reported as a limit; the forecaster's own chance of this, stated with the estimate: 35%; middle value at least 2.5-fold (0.39 log units) away from the limit.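

Compound 1 and compound 3 both stand only as limits in this assay, so no step can be read for hydrogen in place of methyl between them: the limit of > 5000 nM in this assay, at which 2 of the 3 values shown sit.

The compounds shown leave open how far this exchange moves the value, and which group on the ring goes with a measured number such as that of compound 2.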